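Bromo addition on the fused ring of compound 2

The source may report more compounds than this note shows. Statements on the series, on what has been measured and on what is new or still open speak of the compounds shown alone.

Measured in a functional assay on MCF7 cells (Homo sapiens) for inhibition, read by MTT assay, with a stated time of 48 h, tested at 30 ug/mL; on this read-out higher numbers stand for more inhibition of growth at the one concentration tested and lower numbers for less inhibition of growth:
compound 1 `O=c1cc(-c2ccccc2)oc2ccc(N3COc4ccccc4C3)cc12` gives 68.5%
compound 2 `O=c1cc(-c2ccccc2)oc2cc(N3COc4c(Br)cccc4C3)ccc12` gives 7.89%
compound 3 `O=c1cc(-c2ccccc2)oc2ccc(N3COc4c(Br)cccc4C3)cc12` gives 71.6%

Compound 2 stands lowest of the three numbers in this assay; the nearest is compound 1, whose value lies beyond the scatter above it, and compound 3 lies further still.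

The next compound, compound 4 `O=c1cc(-c2ccccc2)oc2cc(N3COc4c(Br)cc(Br)cc4C3)ccc12`, differs from compound 2 by bromo in place of hydrogen on an aromatic carbon.

Among the measured compounds shown here, the one measured step of the same kind, bromo in place of hydrogen on an aromatic carbon, is a number 3.1 percentage points higher from compound 1 to compound 3 (within the scatter), a change within the scatter. That step therefore gives no ground to expect a shift beyond the scatter in this assay for compound 4, in either direction. The estimate means a step of a number 4.1 percentage points higher from compound 2 to compound 4 (within the scatter), expected to stay within the scatter. Compound 4 is thus estimated at about 12%, with a range from 2% to 32%.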

Compound 4, percent growth inhibition at one concentration: 11.1%
Estimate against measurement, compound 4: 0.9 percentage points above; the range from low to high includes it.
By their numbers in this assay, from the lowest: compounds 2 and 4 (each within the scatter of the next); then compounds 1 and 3 (each within the scatter of the next).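

In this assay, bromo in place of hydrogen on this aromatic carbon, meta to a bromo group and para to a fused ring, gives a number 3.2 percentage points higher from compound 2 to compound 4 (within the scatter). Among the compounds shown here, the change, so far seen only on the core of compound 1, therefore also leaves the number on the core of compound 2 within the scatter. The two cores agree on its size: the same change on two cores in this assay, a number 3.1 percentage points higher (within the scatter) from compound 1 to compound 3 and a number 3.2 percentage points higher (within the scatter) from compound 2 to compound 4, 0.1 percentage points apart, within the scatter of two such steps

As far as these compounds go, whether an amine or a carboxylic acid at this position would move the number beyond the scatter remains open. A single concentration also leaves open how the compounds compare across a range of concentrations.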